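The source may report more compounds than this note shows. Statements on the series, on what has been measured and on what is new or still open speak of the compounds shown alone.

Compound 1 `C=CC(=O)Nc1cccc(Nc2ncnc(Nc3ccc(-c4ccc(Cl)nc4)cc3)n2)c1` in a functional assay on Raji cells (Homo sapiens) for antiproliferative activity, read by CCK-8 assay, with a stated time of 24 h (a higher number here means a weaker inhibitor, a lower number a stronger inhibitor), gives "not determined" (no result reported), so it stands nowhere on the numbers shown; the only measured point is compound 2 `C=CC(=O)Nc1cccc(Nc2nc(Cl)nc(Nc3ccc(Oc4ccccc4)cc3)n2)c1`, which in this assay gives 15700 nM. Compound 3 `C=CC(=O)Nc1cccc(Nc2ncnc(Nc3ccc(OC)cc3)n2)c1` is the partner of compound 1 in the change (methoxy in place of 6-chloropyridin-3-yl on an aromatic carbon). Among the compounds with values here, with no value for compound 1, no direction or size of step in this assay can be set against the scatter, and the one measured compound gives only a weak anchor. Compound 3 is expected to give about 20000 nM, estimated between 5000 nM and 80000 nM.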

Compound 3, half-maximal inhibitory concentration: 14500 nM
The estimate for compound 3 lay 1.4-fold (0.14 log units) above the measured number; the measured number falls inside the stated range.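

In this assay, within the data shown here, compound 1 gives "not determined" (no result reported) and so no step to compound 3 can be read. Going by these compounds, whether methoxy in place of 6-chloropyridin-3-yl shifts the activity stays open, and no supporting evidence bears on this result.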